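The source may report more compounds than this note shows. Statements on the series, on what has been measured and on what is new or still open speak of the compounds shown alone.

Compound 1 `O=C(Nc1cccc(F)c1)Nc1cc2ncncc2cc1OCc1cccc(Cl)c1` is one of a small set of ureas built on a shared core carrying an ether-linked aryl group. In a functional assay on GBM3 cells (Homo sapiens) for antiproliferative activity, read by WST assay, with a stated time of 72 h (on this read-out higher numbers stand for weaker inhibition and lower numbers for stronger inhibition), compound 1 gives 8300 nM, the highest of the two plain numbers shown. Within the data shown here, its nearest neighbour, compound 2 `O=C(Nc1ccc(Cl)c(Cl)c1)Nc1cc2ncncc2cc1OCc1cccc(F)c1`, gives 2000 nM in this assay, a gap beyond the scatter; the two differ in two places at once, so their values show only that compound 2 has the lower number. Compound 3 `O=C(Nc1ccc(Cl)c(Cl)c1)Nc1cc2ncncc2cc1OCc1ccccc1F` is reported in this assay as a limit, > 10000 nM, and not as a number.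

Among the measured compounds shown here, the one step that changes a single place is an at least 5.0-fold higher number from compound 2 to compound 3 (0.69 log units; beyond the scatter), and it sits on the chain carbon bound to the ring oxygen, not on the urea side.

Compound 4 `O=C(Nc1ccc(C(F)(F)F)cc1)Nc1cc2ncncc2cc1OCc1cccc(Cl)c1` differs from compound 1 by 4-(trifluoromethyl)phenyl in place of 3-fluorophenyl on an amide-type nitrogen. No measured step touches this position, so the size and direction of the change cannot be read from the data shown; the only single-place step, an at least 5.0-fold higher number from compound 2 to compound 3 (0.69 log units; beyond the scatter), concerns another part of the molecule. Compound 4 is therefore expected to land near compound 1, with a step of a 1.4-fold lower number from compound 1 to compound 4 (0.14 log units; within the scatter) that stays within the scatter. The estimate for compound 4 in this assay is 6000 nM, between 1500 nM and 20000 nM.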

Compound 4, half-maximal inhibitory concentration: 5100 nM
Compound 4: the middle estimate sits 1.2-fold (0.07 log units) above what was measured; measured number inside the range.
By their numbers in this assay, from the lowest: compound 2; then compounds 4 and 1 (each within the scatter of the next). At a limit, above all of these: compound 3.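

Among these compounds, this is the first single-place step on the urea side of the molecule, where 4-(trifluoromethyl)phenyl in place of 3-fluorophenyl on an amide-type nitrogen gives a 1.6-fold lower number from compound 1 to compound 4 (0.21 log units; within the scatter) in this assay. The entering group has more heavy atoms than the one it replaces and carries three fluorines instead of one, yet this exchange shows no change that can be told apart from repeat-to-repeat variation, unlike the step on the ether side, an at least 5.0-fold higher number from compound 2 to compound 3 (0.69 log units; beyond the scatter). Both compounds give plain numbers, so this pair can be compared directly, and the only value that is not a number is the limit reported for compound 3: the limit of > 10000 nM in this assay, at which 1 of the 4 values shown sits.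

The exchange alters both the group on the phenyl ring and the number in its name, so 3-(trifluoromethyl)phenyl or 4-fluorophenyl would be needed to separate those two changes. As far as these compounds go, whether this position stays as unresponsive with an amine or a carboxylic acid on that phenyl ring, or with a saturated ring in place of the phenyl, remains open.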